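A ring swap on the amide of compound 3

The source may report more compounds than this note shows. Statements on the series, on what has been measured and on what is new or still open speak of the compounds shown alone.

Half-lives in an ADME assay on microsomes from liver (Mus musculus, strain CD-1) for metabolic stability, read by LC-MS, tested at 2 uM; a lower number here means that the compound disappears faster, a higher number that the compound lasts longer:
Compound 1 `CNC(=O)c1ccncc1Nc1cc(-c2ccc3ccn(C)c3c2)c2nccnc2c1`: 0.45 h
Compound 2 `Cn1ccc2ccc(-c3cc(Nc4cnccc4C(=O)NC4CCNC(=O)C4)cc4nccnc34)cc21`: > 1 h (a limit of the assay, not a number)
Compound 3 `CN1CC(NC(=O)c2ccncc2Nc2cc(-c3ccc4ccn(C)c4c3)c3nccnc3c2)CCC1=O`: 0.75 h

Compound 3 stands level with compound 1 on these numbers, as a 1.7-fold higher number from compound 1 to compound 3 (0.22 log units; within the scatter) shows. Compound 2 reads > 1 h, which is a limit of this assay. The next compound, compound 4 `CC(=O)N1CCC(NC(=O)c2ccncc2Nc2cc(-c3ccc4ccn(C)c4c3)c3nccnc3c2)C1`, has not yet been measured. It differs from compound 3 as follows: 1-acetylpyrrolidin-3-yl in place of 1-methyl-6-oxopiperidin-3-yl on an amide-type nitrogen. The two have the same atoms, joined differently, with 1-acetylpyrrolidin-3-yl in place of 1-methyl-6-oxopiperidin-3-yl on an amide-type nitrogen.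

Going by the values given here, all the measured steps bear on this same place. Putting a ring group in place of methyl gave an at least 2.2-fold higher number from compound 1 to compound 2 (0.34 log units; beyond the scatter). The same kind of replacement gave the step to compound 3 already noted, which stayed within the scatter. Among the compounds with values here, the only exchange of one ring group for another is an at least 1.3-fold lower number from compound 2 to compound 3 (0.12 log units; that floor lies within the scatter), and its floor also lies within the scatter. On the strength of that exchange, no step beyond the scatter is expected here, and the estimate is a 1.1-fold lower number from compound 3 to compound 4 (0.03 log units; within the scatter). For compound 4 the estimated half-life is 0.7 h, with an expected range from 0.38 h to 1.25 h.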

Compound 4, half-life: 0.667 h
Estimate against measurement, compound 4: 1.0-fold (0.02 log units) above; the range from low to high includes it.
By their numbers in this assay, from the lowest: compounds 1, 4 and 3 (each within the scatter of the next). At a limit, above all of these: compound 2.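

In this assay, the two rings carrying the same atoms read alike: a 1.1-fold lower number from compound 3 to compound 4 (0.05 log units; within the scatter). This means that 1-acetylpyrrolidin-3-yl, a five-membered ring with its carbonyl in an acetyl group, gives no reading apart from 1-methyl-6-oxopiperidin-3-yl, a six-membered ring, on this amide-type nitrogen. Compared with methyl, the new group also stays within the scatter, with a 1.5-fold higher number from compound 1 to compound 4 (0.17 log units; within the scatter), so two of the three ring groups shown do not separate from methyl, and the 2-oxopiperidin-4-yl group of compound 2 is the one that goes against this. The remaining step, an at least 1.4-fold lower number from compound 2 to compound 4 (0.17 log units; that floor lies within the scatter), is only a floor set by a limit of the assay, so its true size cannot be told: the limit of > 1 h in this assay, at which 1 of the 4 values shown sits.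

The compounds shown leave open how much longer the half-life behind that limit really is, and so how far 2-oxopiperidin-4-yl stands from the other ring groups. They also leave open whether an open chain such as 2-acetamidoethyl, or a ring carrying a free amine or a carboxylic acid, would read apart from compound 3 and compound 4 at this position.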